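The compounds below may be only part of what the source reports. "The series", "measured", "known", "first", "only" and "open" are said of these compounds alone.

Three esters of a shared core have been examined in a functional assay on the whole organism (strain Kunming) with Mus musculus as the target, with a stated time of 0.5 h, at a dose of 300 mg/kg by the intraperitoneal route; on this read-out higher numbers stand for a weaker effect at the one dose given and lower numbers for a stronger effect. Compound 1 `COc1ccccc1/C=C/C(=O)OC/C=C/c1cc(OC)c(OC)cc1OC` gives 100%. Compound 2 `COc1cc(OC)c(OC)cc1/C=C/COC(=O)/C=C/c1c(OC)ccc(OC)c1OC` gives 100% in this assay , and compound 3 `COc1cc(OC)c(OC)cc1/C=C/COC(=O)/C=C/c1ccc(F)cc1` gives 100%. Compound 1 therefore stands level with compounds 2 and 3 at the digits shown, and the one step recorded between them, from compound 1 to compound 3, is no change at the digits printed from compound 1 to compound 3 (within the scatter).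

Compound 4 `COc1cc(OC)c(OC)cc1/C=C/COC(=O)/C=C/c1ccccc1Cl` has not yet been measured in this assay . It differs from compound 1 in one place: chloro in place of methoxy on an aromatic carbon. Going by the values given here, the only measured step that bears on this change is the exchange of the group on the same aromatic ring, which amounted to no change at the digits printed from compound 1 to compound 3 (within the scatter). Compound 2, which carries a different substitution pattern on that ring, also gives 100%. Among the compounds with values here, none of the measured compounds moves the read-out beyond the scatter, so the step now expected in this assay is no change at the digits printed from compound 1 to compound 4 (within the scatter). On that basis compound 4 is estimated to give 100% in this assay , with a range from 85% to 100%.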

Compound 4, a percentage reported as activity, at one dose (the size of the read-out at that dose, not a potency): 100%
Estimate against measurement, compound 4: no gap at the digits printed; measured number inside the range.
By their numbers in this assay, from the lowest: compounds 1, 2, 3 and 4 (each within the scatter of the next).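

In this assay, going by these compounds alone, the earlier compounds had only exchanged the whole 2-methoxyphenyl for a 4-fluorophenyl, whereas this result changes the group on the aromatic carbon itself, ortho to a large group: chloro in place of methoxy gives no change at the digits printed from compound 1 to compound 4 (within the scatter), so at this place a single chlorine atom reads the same as the methoxy group. The comparison with the 4-fluorophenyl ester adds that 2-chlorophenyl in its place gives no change at the digits printed from compound 3 to compound 4 (within the scatter), so this read-out separates neither the two halogen-bearing rings nor either of them from the 2-methoxyphenyl ester. Nothing available explains why these exchanges leave the read-out level, and the result is recorded here without a cause.

The compounds shown leave open whether an amine or a carboxylic acid on this aromatic carbon would move the read-out in this assay beyond the usual scatter. They also leave open what would follow from exchanging the methoxy groups on the other aromatic ring, which all four compounds share, for a hydroxy group or a longer alkoxy chain.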